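Stereochemical Inversion at the Ring in a Cytotoxic Azetidine Series

A few compounds are considered here, and "the series" means these few. Any claim that something is new, unique, unknown or untested is made for them only; others in the source may bear on it.

Compound 1 `CCCCCCCCCCCCCC[C@H]1N[C@@H](CO)[C@@H]1O` gives 0.17 ug/mL in a functional assay on HT529 cells (Homo sapiens) for cytotoxicity; on this read-out higher numbers stand for weaker inhibition and lower numbers for stronger inhibition. Compound 2 `CCCCCCCCCCCCCC[C@@H]1N[C@@H](CO)[C@@H]1O` gives 0.56 ug/mL. Compound 3 `CC(C)CC[C@H](O)CCCCCCCCC[C@@H]1N[C@@H](CO)[C@@H]1O` gives a value that is a limit of this assay, > 2 ug/mL. Compound 4 `CCCCCCCCCCCCCC[C@@H]1N[C@H](CO)[C@@H]1O` is not yet measured.

Compound 2 holds the highest of the two numbers shown, with compound 1 nearest, as told by a 3.3-fold higher number from compound 1 to compound 2 (0.52 log units; beyond the scatter). That step is one of configuration only, because of the fact that compounds 1 and 2 differ only in the configuration as drawn, and it is the step that bears on compound 4: the change from compound 2 to compound 4 is the two compounds have the same atoms and bonds and differ only in configuration as drawn: 1 of 3 stereo elements differ; a stereocentre at a saturated ring carbon is drawn S in compound 2 and R in compound 4. The step from compound 2 to compound 3 changes the chain instead, an at least 3.5-fold higher number from compound 2 to compound 3 (0.55 log units; beyond the scatter), and ends at a limit, as the limit of > 2 ug/mL in this assay, at which 1 of the 3 values shown sits, shows, so it speaks less directly to this ring change.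

Since a single inversion at a ring carbon already moved the number modestly between compound 1 and compound 2, a change of similar size in either direction is expected for compound 4, with no clear sign; the estimate for compound 4 is therefore 0.4 ug/mL, between 0.12 ug/mL and 1.5 ug/mL, a step of a 1.4-fold lower number from compound 2 to compound 4 (0.15 log units; within the scatter) expected from compound 2.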

Compound 4, half-maximal inhibitory concentration: > 2 ug/mL
Compound 4: only a limit was reported; the forecaster's own chance of this, stated with the estimate: 10%; middle value at least 5.0-fold (0.69 log units) away from the limit.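

Compound 4 gives only a limit of the assay, > 2 ug/mL. Even so, in this assay this single inversion at a saturated ring carbon gives an at least 3.5-fold higher number from compound 2 to compound 4 (0.55 log units; beyond the scatter), with nothing else altered: the fact that compounds 2 and 4 differ only in the configuration as drawn. With a second ring stereocentre also inverted, the change reaches an at least 11-fold higher number from compound 1 to compound 4 (1.07 log units; beyond the scatter), so configuration alone spans a large step: the fact that compounds 1 and 4 differ only in the configuration as drawn.

On these data alone, how far compound 4 lies past its limit remains open, so both steps have only a lower bound. Also open, as far as these compounds go, are the effect of inverting the third stereocentre and whether a carboxylic acid on the shared core would retain the number of compound 1.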